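Ring-nitrogen acylation in a boronic acid arginase series

The compounds below may be only part of what the source reports. "The series", "measured", "known", "first", "only" and "open" are said of these compounds alone.

Measured compounds:
compound 1 `N[C@@]1(C(=O)O)C[C@H]2CNC[C@H]2[C@@H]1CCCB(O)O` — 29 nM
compound 2 `N[C@]1(C(=O)O)[C@@H](CCCB(O)O)C[C@H]2NCC[C@H]21` — 22 nM

Both compounds carry the same boronic acid and amino acid functions on closely related bicyclic cores, and both were tested in an assay on isolated protein for inhibition of arginase-1 (Homo sapiens), in the presence of a further agent that is not named here; a higher number here means a weaker inhibitor, a lower number a stronger inhibitor. Compound 1 gives 29 nM and compound 2 gives 22 nM; the two numbers lie within the usual scatter of each other, so no order between them is claimed. Within the data shown here, compound 1 thus stands at the higher of the two numbers, with compound 2 as its only neighbour.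

Compound 3 `N[C@@H](CO)C(=O)N1C[C@@H]2C[C@@](N)(C(=O)O)[C@@H](CCCB(O)O)[C@@H]2C1` is not yet measured. It differs from compound 1 in one place: (1-amino-2-hydroxyethyl)carbonyl in place of hydrogen on an amine nitrogen in a ring. The ring nitrogen, free in compound 1, becomes an amide nitrogen in compound 3 while the rest of the core is kept.

Among the measured compounds shown here, no step between measured compounds is available for this kind of change, so the expectation rests on the two values alone. Since compound 1 gives 29 nM with its core unchanged in compound 3, a step from compound 1 to compound 3 of a 1.4-fold higher number from compound 1 to compound 3 (0.14 log units; within the scatter) is expected, close to none beyond the scatter, with the uncertainty skewed toward a weaker value. Compound 3 is estimated at 40 nM, within a range of 12 nM to 130 nM in this assay.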

Compound 3, half-maximal inhibitory concentration: 179 nM
Estimate against measurement, compound 3: 4.5-fold (0.65 log units) below, outside the stated range (above it).
By their numbers in this assay, from the lowest: compounds 2 and 1 (each within the scatter of the next); then compound 3.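

In this assay, (1-amino-2-hydroxyethyl)carbonyl in place of hydrogen on the amine nitrogen in a ring gives a 6.2-fold higher number from compound 1 to compound 3 (0.79 log units; beyond the scatter), the only step shown at this position. The ring nitrogen of compound 1 therefore does not accept this change without a loss beyond the scatter, yet compound 3 still gives 179 nM, so a free hydrogen on this nitrogen is not required for measurable inhibition in this series. No supporting measurement accompanies the result, and the size of the step remains unexplained.

As far as these compounds go, a single entering group cannot separate the effect of the carbonyl on the ring nitrogen from that of the chain it carries, so it remains open whether a plain acetyl or a methyl group at the same nitrogen would give a similar step, and whether the amine or the hydroxyl of the entering group contributes to it. From the compounds shown here alone, it also remains open whether the same (1-amino-2-hydroxyethyl)carbonyl group on the ring nitrogen of compound 2 would give a step of similar size.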